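This account rests on a few compounds, and the source may have more. Where it says the series, first, only, none or still open, it means among the compounds named here.

Measured compounds in an ADME assay on WI-38 cells (Homo sapiens), read by MTT assay, with a stated time of 72 h; on this read-out higher numbers stand for weaker inhibition and lower numbers for stronger inhibition:
compound 1 `COc1cc(NC(C)CCCNC(=O)NC(c2ccccc2)c2ccccc2)c2ncccc2c1`: compound 1 gives > 100000 nM
compound 2 `COc1cc(NC(C)CCCNC(=O)NC2CCCCC2)c2ncccc2c1`: compound 2 gives > 100000 nM

The value of compound 1 is a limit of the assay and not a number. The value of compound 2 is likewise a limit and not a number. Compound 2 therefore stands at the limit of > 100000 nM in this assay, at which 2 of the 2 values shown sit, and nothing in the two values separates it from compound 1. Going by the values given here, no step between measured compounds is available in this assay, so no direction for a change at the amide-type nitrogen has been observed so far.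

Compound 3 `COc1cc(NC(C)CCCNC(=O)NC2CCCC2)c2ncccc2c1` is the compound still to be measured. It differs from compound 2 by cyclopentyl in place of cyclohexyl on an amide-type nitrogen. With both known values sitting at the limit, no trend can be read from the series for this change, and the step from cyclohexyl to cyclopentyl is expected to give nothing beyond the scatter, with compound 3 most likely again reported as a limit. The step that the limit leaves unreadable from compound 2 to compound 3 is the expected outcome. Compound 3 is estimated at 120000 nM, with a range from 50000 nM to 300000 nM.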

Compound 3, half-maximal inhibitory concentration: 29000 nM
Compound 3: the middle estimate sits 4.1-fold (0.62 log units) above what was measured, and the stated range ends above it.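

In this assay, going by these compounds alone, the group on the amide-type nitrogen now shows a readable effect: cyclopentyl in place of cyclohexyl gives an at least 3.4-fold lower number from compound 2 to compound 3 (0.53 log units; beyond the scatter), a change beyond the scatter that the earlier compounds could not show. From the compounds shown here alone, compound 2 gives > 100000 nM, which is a limit and not a number, so the step can be read only as a minimum and its full size remains unknown. Compound 3 is the only compound shown with a value that is a number, while the others remain at the limit: the limit of > 100000 nM in this assay, at which 2 of the 3 values shown sit.

The compounds shown leave open whether a smaller ring such as cyclobutyl or cyclopropyl would continue this direction. Going by these compounds, it is also open whether an open chain such as isopropyl, or a polar group such as an amine, would be tolerated on this nitrogen.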